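Compound 3 to compound 4: losing the 2-(methoxymethoxy)ethoxy group

The source may hold more compounds than are shown below. What is called first, only, known or untested is meant among the compounds shown, and "the series" means these compounds.

Values so far in an ADME assay; a higher number here means that the compound lasts longer, a lower number that the compound disappears faster
compound 1 `CCOc1cc(OC)ccc1C[S+]([O-])c1ncccc1C(=O)Nc1ccncc1` gives < 0.02 h (a limit)
compound 2 `COCOc1cc(OC)ccc1C[S+]([O-])c1ncccc1C(=O)Nc1ccncc1` gives < 0.02 h (a limit)
compound 3 `COCOCCOc1cc(OC)ccc1C[S+]([O-])c1ncccc1C(=O)Nc1ccncc1` gives < 0.02 h (a limit)

Compound 3 gives < 0.02 h and this is a limit, not a number. Within the data shown here, the series so far amounts to the limit of < 0.02 h in this assay, at which 3 of the 3 values shown sit, and holds no readable value, so compound 3 has no measured place relative to the other two compounds.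

Compound 4 `COc1ccc(C[S+]([O-])c2ncccc2C(=O)Nc2ccncc2)cc1` carries hydrogen in place of 2-(methoxymethoxy)ethoxy on an aromatic carbon, ortho to a large group and meta to a methoxy group, with hydrogen in place of 2-(methoxymethoxy)ethoxy on an aromatic carbon as the full difference.

The nearest measured changes are a step that the two limits leave unreadable from compound 1 to compound 2 and a step that the two limits leave unreadable from compound 1 to compound 3 and also a step that the two limits leave unreadable from compound 2 to compound 3 as the third. All three alter the group on this aromatic carbon, but none removes it, and none has a readable size to carry over.

In this assay the expected change is an at least 1.5-fold higher number from compound 3 to compound 4 (0.17 log units; that floor lies within the scatter) and it is only weakly expected to point upward, with a result at the same limit remaining quite possible. The estimate for compound 4 is 0.03 h with an expected range from 0.01 h to 0.3 h as the working figure.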

Compound 4, half-life: 2.14 h
The estimate for compound 4 lay 71-fold (1.85 log units) below the measured number, and the stated range ends below it.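

In this assay, the aromatic carbon ortho to a large group and meta to a methoxy group proves decisive for the read-out. Hydrogen in place of 2-(methoxymethoxy)ethoxy gives an at least 100-fold higher number from compound 3 to compound 4 (2.02 log units; beyond the scatter), hydrogen in place of methoxymethoxy gives an at least 100-fold higher number from compound 2 to compound 4 (2.02 log units; beyond the scatter), and hydrogen in place of ethoxy gives an at least 100-fold higher number from compound 1 to compound 4 (2.02 log units; beyond the scatter). The steps among the three substituted compounds cannot be read, and a readable half-life appears only once the group on this carbon is gone, with the three large steps each starting from a limit and so giving only a minimum size: the limit of < 0.02 h in this assay, at which 3 of the 4 values shown sit.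

The compounds shown leave open whether the number depends on the size of the group at this carbon or on its ether oxygen, since a single fluorine atom, a methyl group or a hydroxyl group there would separate these readings. They also give no cause for the step, and no group smaller than ethoxy at this carbon shows how much of the half-life of compound 4 would remain.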